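Nitro to Methyl Swap and Expected Macrophage Toxicity

This account rests on a few compounds, and the source may have more. Where it says the series, first, only, none or still open, it means among the compounds named here.

Measured compounds:
compound 1, `O=C(/C=C/c1cccc([N+](=O)[O-])c1)NNC(=O)c1ccc2c(c1)OCCO2`, 323000 nM
compound 2, `Cc1cccc(/C=C/C(=O)NNC(=O)c2ccc3c(c2)OCCO3)c1`, 281000 nM
compound 3, `O=C(/C=C/c1ccccc1[N+](=O)[O-])NNC(=O)c1ccc2c(c1)OCCO2`, 257000 nM

Of the compounds shown here, three sharing one core have been tested in an ADME assay on cells (Macrophage) for cytotoxicity, read by MTT assay, with a stated time of 24 h; on this read-out higher numbers stand for lower toxicity in this test and lower numbers for higher toxicity in this test. All three numbers lie close together, and every step among them is within the usual scatter, so none can be called more or less toxic than another.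

Compound 1 and compound 2 differ in a single place: methyl in place of nitro on an aromatic carbon. That change gave a 1.1-fold lower number from compound 1 to compound 2 (0.06 log units; within the scatter). Compound 3 has the same atoms as compound 1 joined differently: 2-nitrophenyl in place of 3-nitrophenyl on a double-bonded chain carbon bound to a double-bonded chain carbon. Between these two the step was a 1.3-fold lower number from compound 1 to compound 3 (0.10 log units; within the scatter). Compound 2 and compound 3 sit a 1.1-fold lower number from compound 2 to compound 3 (0.04 log units; within the scatter) apart.

Compound 4, `Cc1ccccc1/C=C/C(=O)NNC(=O)c1ccc2c(c1)OCCO2`, has not yet been measured in this assay. It differs from compound 3 as follows: methyl in place of nitro on an aromatic carbon. For the measured compounds named here, this is the same kind of change as the one from compound 1 to compound 2, but not the same: there the methyl stood meta to a large group, here it stands ortho to a large group. Because the earlier step of a 1.1-fold lower number from compound 1 to compound 2 (0.06 log units; within the scatter) stayed within scatter, the step from compound 3 to compound 4 is expected to be similarly small, about a 1.1-fold lower number from compound 3 to compound 4 (0.04 log units; within the scatter). Compound 4 is therefore expected to give roughly 235000 nM in this assay, most likely between 120000 nM and 470000 nM.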

Compound 4, half-maximal cytotoxic concentration: 268000 nM
Beside the measured number, compound 4's estimate is 1.1-fold (0.06 log units) below it; measured number inside the range.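

In this assay, putting methyl in place of nitro, here ortho to a large group, gave a 1.0-fold higher number from compound 3 to compound 4 (0.02 log units; within the scatter), and the two other new comparisons are just as small, a 1.0-fold lower number from compound 2 to compound 4 (0.02 log units; within the scatter) and a 1.2-fold lower number from compound 1 to compound 4 (0.08 log units; within the scatter). The swap looks much the same in both settings, whether the group sits as in 3-nitrophenyl or as in 2-nitrophenyl: the same change on two cores in this assay, a 1.1-fold lower number (0.06 log units; within the scatter) from compound 1 to compound 2 and a 1.0-fold higher number (0.02 log units; within the scatter) from compound 3 to compound 4, 1.2-fold (0.08 log units) apart, within the scatter of two such steps. This shows that in these two pairs the exchange of nitro for methyl leaves the number within ordinary measurement noise, but it does not show a real effect that carries over from one core to another, since neither step is large enough to be told apart from noise, and two pairs make no general rule for the series.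

All four compounds shown carry either nitro or methyl on that aromatic ring, and their numbers lie close together, so the comparison says nothing about groups of a different kind. Going by these compounds, it remains open whether an amine or a carboxylic acid on that ring, or a longer chain in place of the double-bonded link, would shift the number beyond the scatter.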